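Removing the chain hydroxy from compound 1

A few compounds are considered here, and "the series" means these few. Any claim that something is new, unique, unknown or untested is made for them only; others in the source may bear on it.

Values in an ADME assay on Vero 76 cells (Chlorocebus sabaeus) for cytotoxicity, read by MTT assay, with a stated time of 120 h (on this read-out lower numbers stand for higher toxicity in this test and higher numbers for lower toxicity in this test), both limits:
- compound 1 `O=C1C2=C(SCCS2)C(=O)N1CC(O)CN1CCN(c2ccc(F)cc2)CC1`: > 100000 nM
- compound 2 `COc1ccccc1N1CCN(CC(O)CN2C(=O)C3=C(SCCS3)C2=O)CC1`: > 100000 nM

Compound 1 stands at a limit, > 100000 nM, and not at a number. the limit of > 100000 nM in this assay, at which 2 of the 2 values shown sit, is all the series shows so far. Compound 3 `O=C1C2=C(SCCS2)C(=O)N1CCCN1CCN(c2ccc(F)cc2)CC1` differs from compound 1 by hydrogen in place of hydroxy on a saturated chain carbon bound to two saturated chain carbons. Among the measured compounds shown here, the only measured step, a step that the two limits leave unreadable from compound 1 to compound 2, changes the aryl group and leaves the hydroxy in place, so it gives no size to carry over. In this assay the expected step is small and towards lower numbers, an at least 1.2-fold lower number from compound 1 to compound 3 (0.09 log units; that floor lies within the scatter). For compound 3 the estimate is 80000 nM, with an expected range from 30000 nM to 100000 nM.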

Compound 3, half-maximal cytotoxic concentration: 96000 nM
Estimate against measurement, compound 3: 1.2-fold (0.08 log units) below, and the stated range covers the measured number.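

In this assay, the change at this position gives an at least 1.0-fold lower number from compound 1 to compound 3 (0.01 log units; that floor lies within the scatter), so hydrogen in place of hydroxy on this saturated chain carbon produces no readable change. Compound 3 gives a number rather than a limit, but the series still sits mostly at one limit: the limit of > 100000 nM in this assay, at which 2 of the 3 values shown sit.

Going by these compounds, an amine on this chain carbon, or a longer chain, remains open in this assay. Also open, on these data alone, is whether the 2-methoxyphenyl series of compound 2 would show the same result without the hydroxy.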